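Notes on replacing the side chain of compound 2

The compounds below may be only part of what the source reports. "The series", "measured", "known", "first", "only" and "open" are said of these compounds alone.

In a functional assay on A549 cells (Homo sapiens) for inhibition, read by MTT assay, with a stated time of 48 h (on this read-out lower numbers stand for stronger inhibition and higher numbers for weaker inhibition), compound 1 `Cc1nc(N(C)c2ccc([Se]C#N)c(C)c2)c2ccccc2n1` gives 8 nM and compound 3 `Cc1nc(N(C)c2ccc([Se]C#N)c(Cl)c2)c2ccccc2n1` gives 7 nM. Compound 2 `COc1ccc(N(C)c2nc(C)nc3ccccc23)cc1C(=O)OCCC[Se]C#N` gives 250 nM, the highest of the three numbers. Compound 4 `COc1ccc(N(C)c2nc(C)nc3ccccc23)cc1OCCCC[Se]C#N` differs from compound 2 by one change: a group of 8 heavy atoms (5 carbon, 1 nitrogen, 1 oxygen, 1 selenium; no ring) in place of a group of 9 heavy atoms (5 carbon, 1 nitrogen, 2 oxygen, 1 selenium; no ring), on an aromatic carbon, ortho to a methoxy group. For the measured compounds named here, the only measured step, a 1.1-fold lower number from compound 1 to compound 3 (0.06 log units; within the scatter), is a chloro in place of methyl elsewhere on the molecule, so it bears on this change only indirectly. Going by the values given here, no measured pair covers this exchange, and compound 2 at 250 nM is the sole anchor. The expected change is a 1.3-fold lower number from compound 2 to compound 4 (0.10 log units; within the scatter), so no shift beyond the scatter is expected in this assay. For compound 4 the estimate is 200 nM, with an expected range of 60 nM to 700 nM.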

Compound 4, half-maximal inhibitory concentration: 1200 nM
The estimate for compound 4 lay 6.0-fold (0.78 log units) below the measured number; measured number outside the range, above it.
By their numbers in this assay, from the lowest: compounds 3 and 1 (each within the scatter of the next); then compound 2; then compound 4.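

At this position, on an aromatic carbon ortho to a methoxy group, the side chain is not interchangeable in this assay: the group of 8 heavy atoms in place of the group of 9 heavy atoms gives a 4.8-fold higher number from compound 2 to compound 4 (0.68 log units; beyond the scatter). For the compounds shown here, this is the first measured step at this position, as the earlier step concerned chloro in place of methyl elsewhere. Nothing available explains this step.

Going by these compounds, whether the step follows from the lost carbonyl or from the chain as a whole remains open. An amide link or a longer chain at this position would bear on that question.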